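Heteroaryl thioether variation at the sulfur of the urea series

This account rests on a few compounds, and the source may have more. Where it says the series, first, only, none or still open, it means among the compounds named here.

Compound 1 `CCCCCCN(CCCCCSc1nc2ccccc2o1)C(=O)Nc1ccc(F)cc1F`, compound 2 `CCCCCCN(CCCCCSc1nc2ccccc2s1)C(=O)Nc1ccc(F)cc1F` and compound 3 `CCCCCCN(CCCCCSc1nc2c([nH]1)CCCC2)C(=O)Nc1ccc(F)cc1F` share one core and differ only in the group attached to the sulfur. In an assay on cells (Macrophage) for inhibition of sterol O-acyltransferase 1 (Mus musculus) (on this read-out lower numbers stand for stronger inhibition and higher numbers for weaker inhibition), compound 1 gives 3500 nM, compound 2 gives 2730 nM and compound 3 gives 2580 nM. Compound 3 gives the lowest of the three numbers, yet it lies within the scatter of both others, and every step here is small: a 1.3-fold lower number from compound 1 to compound 2 (0.11 log units; within the scatter), a 1.4-fold lower number from compound 1 to compound 3 (0.13 log units; within the scatter) and a 1.1-fold lower number from compound 2 to compound 3 (0.02 log units; within the scatter). Compound 4, `CCCCCCN(CCCCCSc1nc2cc([N+](=O)[O-])ccc2[nH]1)C(=O)Nc1ccc(F)cc1F`, is unmeasured; it carries a group of 12 heavy atoms (7 carbon, 3 nitrogen, 2 oxygen; one five-membered aromatic ring with 2 hetero atoms, one six-membered aromatic ring of carbon only) in place of a group of 9 heavy atoms (7 carbon, 2 nitrogen; one five-membered aromatic ring with 2 hetero atoms, one six-membered non-aromatic ring of carbon only), on a sulfur. All three measured steps touch this same position and none left the scatter, so no step beyond the scatter is expected for a 1.1-fold higher number from compound 3 to compound 4 (0.04 log units; within the scatter). For compound 4 the estimate in this assay is 2800 nM, with a range from 1200 nM to 6500 nM.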

Compound 4, half-maximal inhibitory concentration: 8330 nM
Compound 4: middle estimate off by 3.0-fold (0.47 log units), on the low side; the measured number lies above the stated range.
By their numbers in this assay, from the lowest: compounds 3, 2 and 1 (each within the scatter of the next); then compound 4.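

This position is not indifferent to the group on the sulfur: in this assay 5-nitro-1H-benzimidazol-2-yl leaves the scatter against all three earlier groups, with a 3.2-fold higher number from compound 3 to compound 4 (0.51 log units; beyond the scatter) and a 3.1-fold higher number from compound 2 to compound 4 (0.48 log units; beyond the scatter) and a 2.4-fold higher number from compound 1 to compound 4 (0.38 log units; beyond the scatter) in the same direction. All three steps are modest, and compound 4 alone stands apart from compounds 1, 2 and 3. No measurement at hand explains this step.

Open, on these data alone, is whether the step follows the nitro group or the benzimidazole itself. An unsubstituted 1H-benzimidazol-2-yl, or an amine in place of the nitro group, would separate the two.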